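A few compounds are considered here, and "the series" means these few. Any claim that something is new, unique, unknown or untested is made for them only; others in the source may bear on it.

Measured in a functional assay on HEK293 cells for agonist activity at Vasopressin V2 receptor (Homo sapiens), read by a luciferase reporter and cAMP accumulation; on this read-out higher numbers stand for an effect only at larger amounts of compound and lower numbers for an effect already at smaller amounts:
compound 1, `Cc1cc(C(=O)N2CCCCc3ccccc32)ccc1CNC(=O)Nc1ccccc1F`, gives 30 nM
compound 2, `Cc1cc(C(=O)N2CCCCc3ccccc32)ccc1CNC(=O)Nc1ccccc1`, gives 130 nM
compound 3, `Cc1cc(C(=O)N2CCCCc3ccccc32)ccc1CNC(=O)NCC(=O)OC(C)C`, gives 140 nM

Compound 3 carries the highest number of the three in this assay, though the gap a 1.1-fold higher number from compound 2 to compound 3 (0.03 log units; within the scatter) keeps it within the scatter of compound 2, while the gap a 4.7-fold higher number from compound 1 to compound 3 (0.67 log units; beyond the scatter) sets it apart from compound 1. Compound 4, `Cc1cc(C(=O)N2CCCCc3ccccc32)ccc1CNC(=O)NCC(=O)OC(C)(C)C`, differs from compound 3 by methyl in place of hydrogen on a saturated chain carbon bound to an oxygen next to a carbonyl group and two saturated chain carbons. For the measured compounds named here, no measured step touches that part of the chain: the steps of a 4.3-fold higher number from compound 1 to compound 2 (0.64 log units; beyond the scatter) and a 4.7-fold higher number from compound 1 to compound 3 (0.67 log units; beyond the scatter) both change what sits on the urea nitrogen, not the ester end. With nothing bearing directly on the change, the expected step of no change at the digits printed from compound 3 to compound 4 (within the scatter) is none beyond the scatter. Compound 4 is therefore estimated at 140 nM in this assay, within a range of 60 nM to 350 nM.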

Compound 4, half-maximal effective concentration: 120 nM
Estimate against measurement, compound 4: 1.2-fold (0.07 log units) above; the measured number falls inside the stated range.
By their numbers in this assay, from the lowest: compound 1; then compounds 4, 2 and 3 (each within the scatter of the next).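

In this assay, for the compounds shown here, replacing isopropoxy with tert-butoxy gives a 1.2-fold lower number from compound 3 to compound 4 (0.07 log units; within the scatter) and so shows that this ester end, untouched by the earlier steps, accepts the added methyl without a readable change. On the amide-type nitrogen, (tert-butoxycarbonyl)methyl matches phenyl, with a 1.1-fold lower number from compound 2 to compound 4 (0.03 log units; within the scatter), yet it stays apart from 2-fluorophenyl, with a 4.0-fold higher number from compound 1 to compound 4 (0.60 log units; beyond the scatter), as the isopropyl ester did. Nothing available accounts for these results.

Going by these compounds, it remains open whether a carboxylic acid or a benzyl ester at this end would hold the number. Also open, on these data alone, is whether any ester can reach the level of compound 1.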